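Swapping Hydrogen for Methyl on a Growth Inhibitor

The compounds below may be only part of what the source reports. "The series", "measured", "known", "first", "only" and "open" are said of these compounds alone.

Compound 1 `S=C(N/N=C/c1cccs1)Nc1ccc(Cl)cc1`: 2000 nM
Compound 2 `S=C(N/N=C/c1cccs1)Nc1ccccc1`: 16700 nM
Compound 3 `S=C(N/N=C/c1cccs1)Nc1cccnc1`: 16400 nM

In a functional assay on K562 cells (Homo sapiens) for inhibition, read by sulforhodamine B assay, with a stated time of 48 h (a higher number here means a weaker inhibitor of growth, a lower number a stronger inhibitor of growth), compound 2 gives 16700 nM. This lies within the scatter of compound 3, which gives 16400 nM, so the two cannot be told apart. Set against compound 2, compound 1 stands apart, with its clearly lower number of 2000 nM.

The unmeasured compound 4 `Cc1ccc(NC(=S)N/N=C/c2cccs2)cc1` differs from compound 2 in one place: methyl in place of hydrogen on an aromatic carbon. In words, methyl takes the place of hydrogen on an aromatic carbon, para to a large group.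

Within the data shown here, only one measured step offers a guide. Compound 1 carries chloro on the ring where compound 2 has hydrogen, and that swap gives an 8.4-fold higher number from compound 1 to compound 2 (0.92 log units; beyond the scatter), a modest step beyond the scatter. Read backwards, it shows a substituent on this ring going with a lower number. But chloro is not methyl, and no methyl compound has been measured here, so this single example is only a loose guide. A smaller step in the same direction therefore seems the most reasonable expectation, and no change at all cannot be ruled out.

The expected step is a 2.4-fold lower number from compound 2 to compound 4 (0.38 log units; beyond the scatter). For compound 4 the estimated value is 7000 nM, with an expected range of 2500 nM to 18000 nM.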

Compound 4, concentration for 50% growth inhibition: < 900 nM
Compound 4: a limit, no number; the forecaster's own chance of this, stated with the estimate: 2%; at least 7.7-fold (0.89 log units) between middle value and limit.
By their numbers in this assay, from the lowest: compound 1; then compounds 3 and 2 (each within the scatter of the next). At a limit, below all of these: compound 4.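

In this assay compound 4 gives < 900 nM, which is a limit and not a number: the limit of < 900 nM in this assay, at which 1 of the 4 values shown sits.

Methyl in place of hydrogen on an aromatic carbon, para to a large group, gives an at least 18-fold lower number from compound 2 to compound 4 (1.26 log units; beyond the scatter), so this position responds strongly to a single added carbon, and chloro in compound 1 is no longer the only substituent shown to lower the number here. Methyl in place of chloro at the same place gives an at least 2.2-fold lower number from compound 1 to compound 4 (0.34 log units; beyond the scatter), which shows that the choice of substituent matters at this position, and that the presence of any substituent is not the whole story.

The compounds shown leave open how far the true value of compound 4 lies past its limit, so the full size of both steps remains unknown. They also leave open whether an ethyl group, a methoxy group or an amine at this same place would lower the number further or raise it again, and whether methyl would do the same on another carbon of this ring.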